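The compounds below may be only part of what the source reports. "The series", "measured", "known", "first", "only" and "open" are said of these compounds alone.

Measured so far in an assay on HEK293 cells for binding affinity to Neuropeptide Y receptor type 5 (Homo sapiens); a lower number here means a stronger inhibitor, a higher number a weaker inhibitor:
- compound 1 `O=C(NC1CCc2cc(F)ccc2C1Cc1cccnc1)[C@H]1CC[C@H](CNS(=O)(=O)c2ccccc2F)CC1`: 12 nM
- compound 2 `COc1ccc2c(c1)CCC(NC[C@H]1CC[C@H](CNS(=O)(=O)c3ccccc3)CC1)C2Cc1cccnc1`: 10 nM
- compound 3 `O=S(=O)(NC[C@H]1CC[C@H](CNC2CCc3cc(F)ccc3C2Cc2cccnc2)CC1)c1ccccc1`: 27 nM

Compound 3 carries the highest number of the three in this assay; compound 1 sits nearest to it and compound 2 furthest. Among the measured compounds shown here, the one single-point step within the set, a 2.7-fold higher number from compound 2 to compound 3 (0.43 log units; beyond the scatter), concerns the core and not the sulfonyl end.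

Compound 4 `O=S(=O)(NC[C@H]1CC[C@H](CNC2CCc3cc(F)ccc3C2Cc2cccnc2)CC1)c1ccccc1F` differs from compound 3 by fluoro in place of hydrogen on an aromatic carbon. For the measured compounds named here, no measured pair isolates this change. Compound 1 already carries the 2-fluorophenylsulfonyl and gives 12 nM, whereas compound 3 with the plain phenylsulfonyl gives 27 nM, but these two compounds also differ in the linkage of the shared core, so their values show only that both sit in the same range. With nothing in the data pointing to a large effect of this substitution, a small step in this assay is expected for compound 4, at most a modest move toward a lower number, as a 1.6-fold lower number from compound 3 to compound 4 (0.20 log units; within the scatter). Compound 4 is therefore estimated at 17 nM, within 7 nM to 40 nM.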

Compound 4, half-maximal inhibitory concentration: 19 nM
Beside the measured number, compound 4's estimate is 1.1-fold (0.05 log units) below it; the measured number falls inside the stated range.
By their numbers in this assay, from the lowest: compounds 2, 1, 4 and 3 (each within the scatter of the next, the first and the last beyond it).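

In this assay, among the compounds shown here, the change from phenyl to 2-fluorophenyl at the sulfonyl end gives a 1.4-fold lower number from compound 3 to compound 4 (0.15 log units; within the scatter), and this is the first measured pair in which this change stands alone. At this place, ortho to a large group, a fluoro in place of hydrogen therefore leaves the number within the scatter, at least on the core shared by these two compounds. The data on hand offer no explanation for this result.

The compounds shown leave open whether a larger group at the same place, such as chloro, trifluoromethyl or nitrile, would move the number beyond the scatter. They also leave open whether the same fluoro step would read alike on the methoxy-bearing core of compound 2.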